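A few compounds are considered here, and "the series" means these few. Any claim that something is new, unique, unknown or untested is made for them only; others in the source may bear on it.

Compound 1 `CCC(C(=O)N1CCN(c2cccc(C(F)(F)F)c2)CC1)N1C(=O)CCC1=O` carries a trifluoromethyl group on the aromatic ring and an ethyl-bearing chain, and in a functional assay on the whole organism (strain Swiss) with Mus musculus as the target, in the maximal electroshock model, with a stated time of 0.25 h, at a dose of 300 mg/kg by the intraperitoneal route (on this read-out higher numbers stand for a stronger effect at the one dose given and lower numbers for a weaker effect), compound 1 gives 75%. Compound 2 `CCC(C(=O)N1CCN(c2cccc(C)c2)CC1)N1C(=O)CCC1=O` differs from it by methyl in place of trifluoromethyl on an aromatic carbon, and in this assay compound 2 gives 100%. The step that this change made is a number 25 percentage points higher from compound 1 to compound 2 (beyond the scatter). Compound 3 `CC(C(=O)N1CCN(c2cccc(C(F)(F)F)c2)CC1)N1C(=O)CCC1=O` differs from compound 1 by hydrogen in place of methyl on a saturated chain carbon, two bonds along the chain from an amide-type nitrogen in a ring and a carbonyl carbon; in this assay compound 3 gives 75%, and the corresponding step is no change at the digits printed from compound 1 to compound 3 (within the scatter), so compound 3 and compound 1 stand level within the scatter of this assay, and together they hold the lowest two numbers of the three measured.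

Compound 4 `Cc1cccc(N2CCN(C(=O)C(C)N3C(=O)CCC3=O)CC2)c1` has not yet been measured. It differs from compound 3 by methyl in place of trifluoromethyl on an aromatic carbon. This is the same change that was made from compound 1 to compound 2, both of which have been measured; among the compounds here it occurs two times in all, and the place it acts on is described in the same words in both cases. The cores of compound 3 and compound 1 differ by the change described above, a hydrogen for a methyl on the chain.

Because the earlier step in this assay was a number 25 percentage points higher from compound 1 to compound 2 (beyond the scatter), and because compound 3 starts from 75%, the same change is expected to carry compound 4 upward by about a number 20 percentage points higher from compound 3 to compound 4 (beyond the scatter). The read-out cannot rise beyond full effect, which bounds the expected gain. Compound 4 is therefore estimated to give 95% in this assay, with a range expected from 75% to 100%.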

Compound 4, a percentage reported as activity, at one dose (the size of the read-out at that dose, not a potency): 100%
Compound 4: the middle estimate sits 5 percentage points below what was measured; the range from low to high includes it.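

In this assay, methyl in place of trifluoromethyl on the aromatic carbon gave a number 25 percentage points higher from compound 3 to compound 4 (beyond the scatter), and the change carried over unchanged in size from one core to the other: the same change on two cores in this assay, a number 25 percentage points higher (beyond the scatter) from compound 1 to compound 2 and a number 25 percentage points higher (beyond the scatter) from compound 3 to compound 4, 0 percentage points apart, within the scatter of two such steps. Hydrogen in place of methyl on the chain gave no change at the digits printed from compound 2 to compound 4 (within the scatter), and this step also matched its counterpart on the other pair of compounds: the same change on two cores in this assay, no change at the digits printed (within the scatter) from compound 1 to compound 3 and no change at the digits printed (within the scatter) from compound 2 to compound 4, 0 percentage points apart, within the scatter of two such steps. Within the data shown here, this agreement rests on only two cores and a single dose, and since compound 2 gives 100% and compound 4 gives 100%, both at full effect, the read-out cannot show whether methyl brought a larger gain on either core or whether the chain change makes a difference among the methyl compounds.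

The compounds shown leave open how a chlorine or a methoxy group on that aromatic carbon would compare with methyl and trifluoromethyl, and whether a longer chain in place of the methyl or ethyl on the saturated chain carbon would hold the same level. They also leave open whether the two changes would still behave alike at lower doses, where the read-out would have room to separate compound 2 from compound 4.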